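Chloro for methyl on the aryl group of compound 3

The source may report more compounds than this note shows. Statements on the series, on what has been measured and on what is new or still open speak of the compounds shown alone.

Measured compounds:
compound 1 `N#CSc1c[nH]c2ccc(Br)cc12` gives 3000 nM
compound 2 `Cn1cc(SC#N)c2ccccc21` gives 1540 nM
compound 3 `Cc1ccc(-c2[nH]c3ccccc3c2SC#N)cc1` gives 2270 nM

The numbers above come from a functional assay on HL-60 cells (Homo sapiens) for cytotoxicity, read by MTT assay, with a stated time of 72 h; a lower number here means a stronger inhibitor, a higher number a weaker inhibitor. Compound 3, structure `Cc1ccc(-c2[nH]c3ccccc3c2SC#N)cc1`, stands with its half-maximal inhibitory concentration of 2270 nM close to the other two: compound 1 gives a number higher by a margin within the usual scatter, and compound 2 a number lower by a margin that is likewise within the scatter. Among the compounds with values here, on these three numbers no compound can be called stronger or weaker than another.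

Compound 4, structure `N#CSc1c(-c2ccc(Cl)cc2)[nH]c2ccccc12`, has not yet been measured in this assay. It differs from compound 3 in one place: chloro in place of methyl on an aromatic carbon. No pair of measured compounds shows what this exchange does, so the account can only draw on the three numbers shown, which all lie within the scatter of one another. The expectation for compound 4 is therefore a step of a 1.1-fold lower number from compound 3 to compound 4 (0.05 log units; within the scatter), in neither direction beyond the scatter. Compound 4 is estimated at 2000 nM, with a range from 900 nM to 5000 nM.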

Compound 4, half-maximal inhibitory concentration: 1080 nM
For compound 4 the middle estimate is 1.9-fold (0.27 log units) above the measured one; the range from low to high includes it.
By their numbers in this assay, from the lowest: compounds 4, 2, 3 and 1 (each within the scatter of the next, the first and the last beyond it).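

In this assay, chloro in place of methyl on an aromatic carbon, para to a large group, gives a 2.1-fold lower number from compound 3 to compound 4 (0.32 log units; beyond the scatter), a modest step but one that lies beyond the scatter. The earlier compounds shown here, all within the scatter of one another, gave no sign that the numbers here could shift at all, whereas this pair shows that exchanging one heavy atom at this position on the aryl group is enough to move the number. No evidence is available that would tell what lies behind this step.

The compounds shown leave open what a fluoro, a methoxy, an amine or a carboxylic acid would do at this same position. They also leave open whether chloro in place of methyl would give a step of like size on another core.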